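This account rests on a few compounds, and the source may have more. Where it says the series, first, only, none or still open, it means among the compounds named here.

For the measured compounds named here, only two compounds have been measured so far in a physicochemical assay for lipophilicity; a lower number here means a more polar compound, a higher number a more lipophilic compound. Compound 1 `Cc1cc(=O)c(O)c(CN2CCCCC2)n1C` gives 0.559, and compound 2 `O=c1cc(CN2CCCCC2)n(CCN2CCCCC2)cc1O` gives 1.84. Compound 2 therefore holds the higher of the two numbers, and its gap to compound 1 lies beyond the scatter of repeated measurements.

The next compound, compound 3 `Cn1cc(O)c(=O)cc1CN1CCCCC1`, differs from compound 2 in one place: hydrogen in place of (piperidin-1-yl)methyl on a saturated chain carbon bound to an aromatic nitrogen. In words, hydrogen stands in place of (piperidin-1-yl)methyl on a saturated chain carbon bound to an aromatic nitrogen.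

Going by the values given here, no measured pair shows this change, so its size cannot be read directly from the data. A clear fall in this assay, beyond the scatter, is still expected. The only low reference point is compound 1 at 0.559, and compound 3 is expected to land in that region. This forecast rests on very little evidence, so the range must stay wide. The expected change is a number 1.54 log units lower from compound 2 to compound 3 (beyond the scatter). For compound 3 the estimated value is 0.3, within an expected range of -0.2 to 0.8.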

Compound 3, partition coefficient: 0.64
Estimate against measurement, compound 3: 0.34 log units below, within the range that was stated.
By their numbers in this assay, from the lowest: compounds 1 and 3 (each within the scatter of the next); then compound 2.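

For the compounds shown here, compound 2 and compound 3 form the first measured pair that differs in one place, so the size of this change can now be read directly. On a saturated chain carbon bound to an aromatic nitrogen, hydrogen in place of (piperidin-1-yl)methyl gives in this assay a step of a number 1.20 log units lower from compound 2 to compound 3 (beyond the scatter) and so this position clearly matters for the number, at least when a piece of 7 heavy atoms, including one six-membered non-aromatic ring, leaves. No supporting measurement is available to explain the size of this step.

On these data alone, a single pair gives only the two end points, so it remains open whether a smaller group on the same carbon, such as a methyl, a short unbranched propyl chain or a carboxylic acid, would give a number close to that of compound 3 or that of compound 2. As far as these compounds go, it is also open whether the step follows the ring's carbon atoms or its nitrogen, a question that a cyclohexylmethyl group, which has the ring but no nitrogen, could help to separate.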